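This account rests on a few compounds, and the source may have more. Where it says the series, first, only, none or still open, it means among the compounds named here.

Compound 2 `CCC(C)(C)Cc1c[nH]c(CCc2ccc(-n3ncnn3)cc2)n1` gives the highest number of the three compounds measured in a functional assay on HEK293 cells for agonist activity at Bombesin receptor subtype-3 (Mus musculus), read by luminescence and calcium flux, with a stated time of 10 min (a higher number here means that more compound is needed for the effect, a lower number that less compound is needed), at 25 nM; compound 1 `CCC(C)(C)Cc1c[nH]c(CCc2ccc(-c3cccc(N)n3)cc2)n1` gives 3.9 nM and compound 3 `O=C(O)c1cc(F)c(F)cc1-c1ccc(CCc2nc(CC3CCCCC3)c[nH]2)cc1` gives 4.7 nM. Compound 4 `CCC(C)(C)Cc1c[nH]c(CCc2ccc(-c3ccns3)cc2)n1` differs from compound 2 by 1,2-thiazol-5-yl in place of 2H-tetrazol-2-yl on an aromatic carbon. Within the data shown here, the one measured step that bears on this is a 6.4-fold higher number from compound 1 to compound 2 (0.81 log units; beyond the scatter), which shows that exchanging the group on that aromatic carbon can move the number by a modest amount. Among the measured compounds shown here, no measured pair sets 1,2-thiazol-5-yl against 2H-tetrazol-2-yl, so the direction is uncertain; since compound 2 sits at the high end, a modest move toward lower numbers is expected, a 2.1-fold lower number from compound 2 to compound 4 (0.32 log units; beyond the scatter). Compound 4 is estimated at 12 nM, with a range from 4 nM to 40 nM.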

Compound 4, half-maximal effective concentration: 3.1 nM
Beside the measured number, compound 4's estimate is 3.9-fold (0.59 log units) above it, outside the stated range (below it).
By their numbers in this assay, from the lowest: compounds 4, 1 and 3 (each within the scatter of the next); then compound 2.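

Exchanging 2H-tetrazol-2-yl for 1,2-thiazol-5-yl gives an 8.1-fold lower number from compound 2 to compound 4 (0.91 log units; beyond the scatter), so two five-membered aromatic rings of equal heavy-atom count are not interchangeable on this aromatic carbon. The step of a 1.3-fold lower number from compound 1 to compound 4 (0.10 log units; within the scatter) places 1,2-thiazol-5-yl level with 6-aminopyridin-2-yl, showing that neither the six-membered ring nor its amine is needed to reach this level. No measurement here explains the gap between the two five-membered rings. The compounds shown leave open whether a pyrazole or an oxazole on this carbon would sit nearer compound 4 or compound 2.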